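The source may report more compounds than this note shows. Statements on the series, on what has been measured and on what is new or still open speak of the compounds shown alone.

Compound 1 `CCOC(=O)C1=C(C)NC(C)=C(C(=O)OCC)C1c1ccc(OCC(=O)NCc2ccccc2)cc1`: 31.1%
Compound 2 `CCOC(=O)C1=C(C)NC(C)=C(C(=O)OCC)C1c1ccc(OCC(=O)Nc2ccc(C)cc2)cc1`: 61.1%
Compound 3 `CCOC(=O)C1=C(C)NC(C)=C(C(=O)OCC)C1c1ccc(OCC(=O)Nc2nc3ccccc3s2)cc1`: 65.9%

In a functional assay on the whole organism (strain Wistar) for inhibition, with Rattus norvegicus as the target, read by paw edema, with stated times of 30 min and 3 h, at a dose of 20 mg/kg (on this read-out lower numbers stand for less inhibition and higher numbers for more inhibition at the one dose given (going by the name of the read-out)), compound 2 gives 61.1%, the second highest of the three numbers. The step of a number 4.8 percentage points higher from compound 2 to compound 3 (within the scatter) stays within the scatter, while a number 30 percentage points higher from compound 1 to compound 2 (beyond the scatter) lies beyond it. Compound 4 `CCOC(=O)C1=C(C)NC(C)=C(C(=O)OCC)C1c1ccc(OCC(=O)NNC(=O)c2ccc(C)cc2)cc1` differs from compound 2 in one place: ((4-methylphenyl)carbonyl)amino in place of 4-methylphenyl on an amide-type nitrogen. All measured steps vary the group on this same amide-type nitrogen: a number 34.8 percentage points higher from compound 1 to compound 3 (beyond the scatter) was large, a number 30 percentage points higher from compound 1 to compound 2 (beyond the scatter) modest, and the exchange of one aromatic group for another, a number 4.8 percentage points higher from compound 2 to compound 3 (within the scatter), fell within the scatter. For the measured compounds named here, no measured step inserts a carbonylamino link, so the expectation remains loose. Compound 4 is expected to give 50% (35% to 65%), an estimated step of a number 11.1 percentage points lower from compound 2 to compound 4 (beyond the scatter) that may well stay within the scatter.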

Compound 4, a percentage reported as inhibition, in the whole organism at one dose (the size of the read-out at that dose, not a potency): 47.3%
For compound 4 the middle estimate is 2.7 percentage points above the measured one; the measured number falls inside the stated range.
By their numbers in this assay, from the lowest: compound 1; then compound 4; then compounds 2 and 3 (each within the scatter of the next).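

Placing a carbonylamino link before the 4-methylphenyl group on the amide-type nitrogen lowers the response in this assay (a number 13.8 percentage points lower from compound 2 to compound 4 (beyond the scatter)). The new group also falls short of 1,3-benzothiazol-2-yl (a number 18.6 percentage points lower from compound 3 to compound 4 (beyond the scatter)) but exceeds benzyl (a number 16.2 percentage points higher from compound 1 to compound 4 (beyond the scatter)), so this position yields an intermediate level between the benzyl compound and the two compounds with an aromatic ring directly on the nitrogen. No available evidence bears on the reason for these differences.

On these data alone, it remains open whether the carbonyl or the added nitrogen accounts for the drop. As far as these compounds go, how an aliphatic amine or a carboxylic acid on a longer chain would read at this nitrogen also remains open.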